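The compounds below may be only part of what the source reports. "The series", "measured", "known", "first", "only" and "open" are said of these compounds alone.

Measured so far in a functional assay on HCT-116 cells (Homo sapiens) for antiproliferative activity, read by MTT assay; a higher number here means a weaker inhibitor, a lower number a stronger inhibitor:
compound 1 `CN1CCN(c2ccc(Nc3ncc(/N=C/c4ccc(C(F)(F)F)cc4)c(NC4CCCC4)n3)cc2)CC1` gives > 100000 nM, a limit of the assay rather than a number
compound 2 `CC(C)Nc1nc(Nc2ccc(N3CCN(C)CC3)cc2)ncc1/N=C/c1ccccc1` gives > 100000 nM, also a limit
compound 3 `CC(C)Nc1nc(Nc2ccc(N3CCN(C)CC3)cc2)ncc1/N=C/c1ccc(C(F)(F)F)cc1` gives 42200 nM

For the measured compounds named here, compound 3 thus holds the only numerical value in this assay; the two other entries are limits. Two single-point steps lead to compound 3: an at least 2.3-fold lower number from compound 1 to compound 3 (0.37 log units; beyond the scatter), and an at least 2.3-fold lower number from compound 2 to compound 3 (0.37 log units; beyond the scatter). Both steps are known only as lower bounds because of the limit of > 100000 nM in this assay, at which 2 of the 3 values shown sit.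

Compound 4 `CC(C)Nc1nc(Nc2ccc(S(N)(=O)=O)cc2)ncc1/N=C/c1ccc(C(F)(F)F)cc1` differs from compound 3 by sulfamoyl in place of 4-methylpiperazin-1-yl on an aromatic carbon. Neither measured step touches this change: one swaps isopropyl for cyclopentyl on a nitrogen on an aromatic ring, the other puts trifluoromethyl in place of hydrogen on an aromatic carbon. For the exchange of 4-methylpiperazin-1-yl against sulfamoyl there is no measured guide within this series, and compound 3 itself sits close to the limit of this assay. The working expectation is therefore no step beyond the scatter in either direction, with wide uncertainty and a real chance that only a limit is returned. Compound 4 is accordingly expected to give about 45000 nM in this assay, within 8000 nM to 150000 nM. The expected step is then a 1.1-fold higher number from compound 3 to compound 4 (0.03 log units; within the scatter).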

Compound 4, half-maximal inhibitory concentration: > 100000 nM
Compound 4 ended at the assay's limit; the forecaster's own chance of this, stated with the estimate: 35%; middle value at least 2.2-fold (0.34 log units) from the limit.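

In this assay, for the compounds shown here, the earlier steps touched only the group on the nitrogen and the trifluoromethyl place, so this is the first reading at the aromatic carbon that carries 4-methylpiperazin-1-yl in compound 3, and sulfamoyl there gives an at least 2.3-fold higher number from compound 3 to compound 4 (0.37 log units; beyond the scatter). Going by these compounds alone, with isopropyl and trifluoromethyl held constant, this position is therefore not indifferent to the exchange, and the one change tried here takes the series away from its only numerical value. Compound 4 gives > 100000 nM, a limit of the assay and not a number, so the step is a lower bound and its true size cannot be read: the limit of > 100000 nM in this assay, at which 3 of the 4 values shown sit.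

Whether the step belongs to sulfamoyl itself or to the removal of 4-methylpiperazin-1-yl stays open, as the compounds shown hold no other group at this place, such as an open-chain amine, a morpholine ring or a carboxylic acid. Also open, going by these compounds, is how sulfamoyl reads with cyclopentyl in place of isopropyl, or with hydrogen in place of trifluoromethyl.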